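The source may hold more compounds than are shown below. What is called first, only, known or untested is meant among the compounds shown, and "the series" means these compounds.

Measured compounds:

Compound 1, `CC(C)c1ccc(N2C(=O)C=CC2OCC(F)(F)F)cc1`, in a functional assay on A549 cells (Homo sapiens) for inhibition (a lower number here means a stronger inhibitor, a higher number a weaker inhibitor), gives 9570 nM.
Compound 2, `O=C1C=CC(OCC(F)(F)F)N1c1ccccc1`, gives 23400 nM.
Compound 3, `COC(=O)c1ccc(N2C(=O)C=CC2OCC(F)(F)F)cc1`, gives 8170 nM.

Compound 3 has the lowest of the three numbers. Its nearest neighbour is compound 1, and that pair sits within the scatter, so the two cannot be told apart; the furthest is compound 2, and there the gap is beyond the scatter, as the step of a 2.9-fold lower number from compound 2 to compound 3 (0.46 log units; beyond the scatter) shows.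

Compound 4, `CC(C)(C)c1ccc(N2C(=O)C=CC2OCC(F)(F)F)cc1`, differs from compound 3 in one place: tert-butyl in place of methoxycarbonyl on an aromatic carbon. Going by the values given here, two measured steps bear on this. The exchange of isopropyl for methoxycarbonyl, a 1.2-fold lower number from compound 1 to compound 3 (0.07 log units; within the scatter), lay within the scatter, so a branched alkyl group and the methoxycarbonyl group at this position give the same kind of number. Removing the isopropyl group altogether, a 2.4-fold higher number from compound 1 to compound 2 (0.39 log units; beyond the scatter), cost a modest amount. Tert-butyl is again a branched alkyl group at this position, so in this assay no step beyond the scatter is expected from compound 3 to compound 4, in either direction.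

Compound 4 is therefore expected to give about 9500 nM, with a range from 4000 nM to 25000 nM. This amounts to an expected step of a 1.2-fold higher number from compound 3 to compound 4 (0.07 log units; within the scatter).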

Compound 4, half-maximal inhibitory concentration: 8500 nM
Estimate against measurement, compound 4: 1.1-fold (0.05 log units) above, within the range that was stated.
By their numbers in this assay, from the lowest: compounds 3, 4 and 1 (each within the scatter of the next); then compound 2.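

In this assay, tert-butyl, with no hydrogen-bond acceptors, takes the place of methoxycarbonyl, with two, and the result stays within the scatter (a 1.0-fold higher number from compound 3 to compound 4 (0.02 log units; within the scatter)), so among these compounds the acceptors of methoxycarbonyl are not required at this position. The added methyl that turns the isopropyl group into tert-butyl also leaves the result within the scatter (a 1.1-fold lower number from compound 1 to compound 4 (0.05 log units; within the scatter)), while a third substituent now stands modestly apart from the unsubstituted ring (a 2.8-fold lower number from compound 2 to compound 4 (0.44 log units; beyond the scatter)), which shows that the advantage over compound 2 is shared by an alkyl pair and an ester. Nothing available gives a cause for this.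

The compounds shown leave open whether an amine, a carboxylic acid or a halogen such as chlorine at this position would move the number beyond the level of compounds 1, 3 and 4. They also leave open how much the rest of the shared core contributes, since it is the same in all four compounds.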